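From a Chlorinated Phenyl to a Hydroxylated One

A few compounds are considered here, and "the series" means these few. Any claim that something is new, unique, unknown or untested is made for them only; others in the source may bear on it.

Of the compounds shown here, three sharing one core have been measured in a functional assay; on this read-out higher numbers stand for weaker inhibition and lower numbers for stronger inhibition. Compound 1 `CC(C)=CCOc1ccc2c(c1)OC(c1ccccc1Cl)CC2=O` gives 8020 nM. Compound 2 `CC(C)=CCOc1ccc2c(c1)OC(c1ccc(Cl)cc1)CC2=O` gives 6970 nM in this assay, so the change a 1.2-fold lower number from compound 1 to compound 2 (0.06 log units; within the scatter) lies within the scatter. Compound 3 `CC(C)=CCOc1cc(O)c2c(c1)OC(c1ccccc1Cl)CC2=O` gives 4270 nM in this assay, and the change a 1.9-fold lower number from compound 1 to compound 3 (0.27 log units; within the scatter) is likewise within the scatter. Compound 3 thus holds the smallest of the three numbers, but its gaps to compound 2 and to compound 1 are both within the scatter, so no ordering of the three can be read from them.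

Compound 4 `CC(C)=CCOc1cc(O)c2c(c1)OC(c1ccc(O)cc1)CC2=O` has not yet been measured. It differs from compound 3 in one place: 4-hydroxyphenyl in place of 2-chlorophenyl on a saturated ring carbon. For the measured compounds named here, only one measured step speaks to this change: the step from compound 1 to compound 2 shifted the same chlorine-bearing phenyl group from one arrangement to the other, and a 1.2-fold lower number from compound 1 to compound 2 (0.06 log units; within the scatter) showed no effect beyond the scatter. Going by the values given here, no measured step swaps chlorine for hydroxy on that phenyl group, so that part of the change is untested here. The expected step of a 1.1-fold lower number from compound 3 to compound 4 (0.03 log units; within the scatter) is therefore small, with no clear direction. Compound 4 is estimated to give 4000 nM in this assay, within a range from 1300 nM to 12000 nM.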

Compound 4, half-maximal inhibitory concentration: 5340 nM
Beside the measured number, compound 4's estimate is 1.3-fold (0.13 log units) below it, and the stated range covers the measured number.
By their numbers in this assay, from the lowest: compounds 3, 4, 2 and 1 (each within the scatter of the next).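

In this assay the swap of 2-chlorophenyl for 4-hydroxyphenyl on the saturated ring carbon gives a 1.3-fold higher number from compound 3 to compound 4 (0.10 log units; within the scatter) and so leaves no effect that can be told from the scatter. The earlier step at this position only moved the chlorine around the phenyl ring, whereas this one also replaces it with a hydroxy group, and the entering group carries a hydrogen-bond donor and a hydrogen-bond acceptor where the leaving group carries neither, yet the read-out does not register the difference. Nothing at hand explains why this exchange leaves the number within the scatter.

This single step changes both the substituent and its place on the phenyl ring, so the compounds shown cannot separate the two, and a 2-hydroxyphenyl or 4-chlorophenyl partner for compound 3 would be needed to pull them apart. Also open, from the compounds shown here alone, is whether a quite different group on that phenyl ring, such as an amine or a carboxylic acid, would produce a step beyond the scatter.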